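A sugar group returns in place of the dioxolane

A few compounds are considered here, and "the series" means these few. Any claim that something is new, unique, unknown or untested is made for them only; others in the source may bear on it.

Compound 1 `O=C1c2c[n+]([O-])c3ccccc3c2C(=O)c2c1c1ccccc1n2Cc1cn([C@@H]2C[C@H](O)[C@@H](CO)O2)nn1`: 130 nM
Compound 2 `CC1(C)OC[C@@H](Cn2cc(Cn3c4c(c5ccccc53)C(=O)c3c[n+]([O-])c5ccccc5c3C4=O)nn2)O1`: > 1000 nM
Compound 3 `O=C1c2c[n+]([O-])c3ccccc3c2C(=O)c2c1c1ccccc1n2Cc1cn([C@H]2C[C@H](O)[C@@H](CO)O2)nn1`: not yet measured

In a functional assay on MDA-MB-231 cells (Homo sapiens) for cytotoxicity, read by MTT assay, with a stated time of 72 h (a lower number here means a stronger inhibitor, a higher number a weaker inhibitor), compound 1 gives 130 nM. Compound 2 gives > 1000 nM, which is a limit and not a number. Compound 2 therefore stands at the limit of > 1000 nM in this assay, at which 1 of the 2 values shown sits.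

The move to compound 3 changes one group: 4-hydroxy-5-(hydroxymethyl)oxolan-2-yl in place of (2,2-dimethyl-1,3-dioxolan-4-yl)methyl on an aromatic nitrogen. Here 4-hydroxy-5-(hydroxymethyl)oxolan-2-yl comes in place of (2,2-dimethyl-1,3-dioxolan-4-yl)methyl on an aromatic nitrogen.

For the measured compounds named here, one measured step bears on this change: an at least 7.6-fold higher number from compound 1 to compound 2 (0.88 log units; beyond the scatter). That step exchanged the same two named groups in the opposite direction, and it lies beyond the scatter. Going by the values given here, its size is only a bound, and it is the sole step of this kind, so the expectation stays broad. A step of similar or greater size is expected in this assay, towards a lower number and so a stronger inhibitor. The estimated change is an at least 4.0-fold lower number from compound 2 to compound 3 (0.60 log units; beyond the scatter). For compound 3 the expected value is 250 nM, with an estimated range from 80 nM to 1000 nM.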

Compound 3, half-maximal inhibitory concentration: 580 nM
Estimate against measurement, compound 3: 2.3-fold (0.37 log units) below, within the range that was stated.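

In this assay compound 2 gives > 1000 nM, which is a limit and not a number: the limit of > 1000 nM in this assay, at which 1 of the 3 values shown sits.

Replacing (2,2-dimethyl-1,3-dioxolan-4-yl)methyl with 4-hydroxy-5-(hydroxymethyl)oxolan-2-yl on the aromatic nitrogen gives an at least 1.7-fold lower number from compound 2 to compound 3 (0.23 log units; that floor lies within the scatter), so with this configuration the sugar group is not shown to improve on the dioxolane group by more than the scatter. The new finding is a 4.5-fold higher number from compound 1 to compound 3 (0.65 log units; beyond the scatter), and this gap can be assigned to one stereocentre at a saturated ring carbon, drawn S in the one compound and R in the other, because of a single fact: the fact that compounds 1 and 3 differ only in the configuration as drawn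

As far as these compounds go, the true size of the step from the dioxolane group remains open, as only a limit stands on that side. Also open, from the compounds shown here alone, are whether the other two stereocentres of the sugar group matter as much as this one, and whether an amine or a carboxylic acid in place of the hydroxy group on the oxolane ring would keep the value of compound 1.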